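The source may report more compounds than this note shows. Statements on the series, on what has been measured and on what is new or still open speak of the compounds shown alone.

Series of three compounds measured in an assay on isolated protein for displacement of a labelled ligand from metabotropic glutamate receptor 5 (Homo sapiens), with a stated time of 60 min, tested at 1 uM; a higher number here means more inhibition at the concentration tested (going by the name of the read-out), a lower number less inhibition. Compound 1, `CC1CCN(c2c(S(=O)(=O)c3ccc(F)cc3)cnc3ccc(F)cc23)CC1`, gives 87%. Compound 2, `CC1CCN(c2c(S(=O)(=O)c3ccc(F)c(F)c3)cnc3ccc(F)cc23)CC1`, gives 82%, and compound 3, `CC1CCN(c2c(S(=O)(=O)c3cccc(F)c3)cnc3ccc(F)cc23)CC1`, gives 76%. Compound 3 carries the lowest of the three numbers: its nearest neighbour is compound 2, and that gap is within the scatter, whereas the gap to compound 1 lies beyond it. The single-point changes among the measured compounds read a number 5 percentage points lower from compound 1 to compound 2 (within the scatter), a number 6 percentage points lower from compound 2 to compound 3 (within the scatter) and a number 11 percentage points lower from compound 1 to compound 3 (beyond the scatter); only the last is beyond the scatter, and even that one is modest.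

The next compound, compound 4, is `CC1CCN(c2c(S(=O)(=O)c3ccc(C#N)cc3)cnc3ccc(F)cc23)CC1`. Compared with compound 3 the change is 4-cyanophenyl in place of 3-fluorophenyl on a sulfonyl sulfur. Within the data shown here, the step bearing on it most directly is a number 11 percentage points lower from compound 1 to compound 3 (beyond the scatter), which also exchanges one fluorophenyl for another on the sulfonyl sulfur; no measured compound carries a nitrile, so that part of the change has no precedent. A return toward the level of compound 1 is the most the numbers support, and the nitrile widens the uncertainty in both directions. The expected step is a number 7 percentage points higher from compound 3 to compound 4 (within the scatter). For compound 4 in this assay the estimate is 83%, with a range from 66% to 95%.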

Compound 4, a percentage reported as inhibition, at one concentration (the size of the read-out at that concentration, not a potency): 75%
The estimate for compound 4 lay 8 percentage points above the measured number; the range from low to high includes it.
By their numbers in this assay, from the lowest: compounds 4, 3, 2 and 1 (each within the scatter of the next, the first and the last beyond it).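

In this assay, among these compounds, the 4-cyanophenyl group on the sulfonyl sulfur is the first group without a fluoro substituent on that ring, and the step to it is a number 1 percentage points lower from compound 3 to compound 4 (within the scatter) and, from the difluorinated analogue, a number 7 percentage points lower from compound 2 to compound 4 (within the scatter); on these numbers it stands level with the 3-fluorophenyl and 3,4-difluorophenyl groups. The direct exchange at the same ring carbon gives a number 12 percentage points lower from compound 1 to compound 4 (beyond the scatter) and so shows what the fluoro-only compounds could not: a substituent at the carbon carrying the fluoro of compound 1 does not by its location alone keep the number at the level of compound 1. Nothing at hand accounts for either step.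

On these data alone, whether a 4-chlorophenyl, a 4-methoxyphenyl or an unsubstituted phenyl on the sulfonyl sulfur would read with compound 1 or with compound 4 remains open. As far as these compounds go, all of these numbers come from a single concentration, so how the compounds rank in potency also remains open, and the modest spread leaves the effect of the ring substituent only loosely defined.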